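Loss of the (1-bromoethenyl)carbonyl group across two cores

The source may hold more compounds than are shown below. What is called first, only, known or untested is meant among the compounds shown, and "the series" means these compounds.

Compound 1 `C=C(Br)C(=O)Nc1ccc(/C=C/C(=O)c2ccc(Cl)cc2)cc1` and compound 3 `Nc1ccc(/C=C/C(=O)c2ccc(Cl)cc2)cc1` share one core; in a functional assay on MOLT-4 cells (Homo sapiens) for antiproliferative activity, with a stated time of 48 h (a lower number here means a stronger inhibitor, a higher number a weaker inhibitor), compound 1 gives 810 nM and compound 3 gives 7800 nM. The change between them, (hydrogen in place of (1-bromoethenyl)carbonyl on a nitrogen on an aromatic ring), made a step of a 9.6-fold higher number from compound 1 to compound 3 (0.98 log units; beyond the scatter). Compound 2 `C=C(Br)C(=O)Nc1ccc(/C=C/C(=O)c2cc(OC)c(OC)c(OC)c2)cc1` carries the same (1-bromoethenyl)carbonyl group on another core; how the core of compound 2 differs from the core of compound 1 is not broken down here. In this assay compound 2 gives 850 nM, within the scatter of compound 1. Compound 4 `COc1cc(C(=O)/C=C/c2ccc(N)cc2)cc(OC)c1OC` is unmeasured and differs from compound 2 by hydrogen in place of (1-bromoethenyl)carbonyl on a nitrogen on an aromatic ring. The place reads the same word for word as in the pair of compound 1 and compound 3, so this is the same change, seen twice among the compounds shown. The step from compound 2 to compound 4 is expected to be a 9.4-fold higher number from compound 2 to compound 4 (0.97 log units; beyond the scatter) in this assay. Within the data shown here, the expectation rests on the single precedent a 9.6-fold higher number from compound 1 to compound 3 (0.98 log units; beyond the scatter), with the starting values of compound 1 and compound 2 within the scatter of each other. Compound 4 is therefore estimated at 8000 nM, with a range from 3500 nM to 18000 nM.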

Compound 4, half-maximal inhibitory concentration: 1500 nM
The estimate for compound 4 lay 5.3-fold (0.73 log units) above the measured number, outside the stated range (below it).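

In this assay, the exchange of ((1-bromoethenyl)carbonyl)amino to amino on the second core gives a 1.8-fold higher number from compound 2 to compound 4 (0.25 log units; within the scatter), so there the step stays within the scatter. The same change therefore does not carry over at one size, and its size differs between these two cores: the same change on two cores in this assay, a 9.6-fold higher number (0.98 log units; beyond the scatter) from compound 1 to compound 3 and a 1.8-fold higher number (0.25 log units; within the scatter) from compound 2 to compound 4, 5.5-fold (0.74 log units) apart, beyond the scatter of two such steps This shows that the step seen on the core of compound 1 cannot be transferred to the core of compound 2 as a fixed increment, but it does not show which part of the cores sets the difference, nor how the step would run on any further core.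

Among these compounds, with only two cores, it remains open which of the two step sizes is more typical of the series. On these data alone, it also remains open whether the step on the core of compound 1 belongs to the bromine or to the rest of the group, a question on which an acetyl or a propenoyl group on the same nitrogen would bear.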